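Swapping the aryl ether ring on a P2X7 antagonist scaffold

The source may report more compounds than this note shows. Statements on the series, on what has been measured and on what is new or still open speak of the compounds shown alone.

Compound 1, `C[C@@H](Cn1c(=O)[nH]/c(=N\c2ccc(Oc3ccccn3)cc2)n(Cc2ccc(Cl)cc2)c1=O)C(=O)O`, and compound 2, `C[C@@H](Cn1c(=O)[nH]/c(=N\c2ccc(Oc3ccnc(F)c3)cc2)n(Cc2ccc(Cl)cc2)c1=O)C(=O)O`, share one core and differ only in the ring carried on an oxygen on an aromatic ring. In an assay on isolated protein for antagonist activity at P2X purinoceptor 7 (Homo sapiens) (on this read-out lower numbers stand for stronger inhibition and higher numbers for weaker inhibition), compound 1 gives only a limit of > 30000 nM. In this assay compound 2 likewise gives only a limit of > 30000 nM. The step that the two limits leave unreadable from compound 1 to compound 2, pyridin-2-yl replaced by 2-fluoropyridin-4-yl, therefore cannot be read in size, and the limit of > 30000 nM in this assay, at which 2 of the 2 values shown sit, is all that the measurements so far show. Compound 3, `C[C@@H](Cn1c(=O)[nH]/c(=N\c2ccc(Oc3ccsn3)cc2)n(Cc2ccc(Cl)cc2)c1=O)C(=O)O`, differs from compound 2 by 1,2-thiazol-3-yl in place of 2-fluoropyridin-4-yl on an oxygen on an aromatic ring. Among the compounds with values here, no measured step bears on this exchange, so the expectation rests on the two limits alone. Compound 3 is expected to remain at or beyond the limit, with an estimated 40000 nM spanning 15000 nM to 100000 nM. The estimated step that the limit leaves unreadable from compound 2 to compound 3 is accordingly expected to show nothing beyond the scatter.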

Compound 3, half-maximal inhibitory concentration: > 30000 nM
Compound 3: a limit, no number; the forecaster's own chance of this, stated with the estimate: 85%; the middle value is on the limit's open side.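

In this assay compound 3 gives > 30000 nM, which is a limit and not a number. The steps to compound 3 from compound 1 and compound 2 therefore cannot be read in size. The compounds shown leave open whether any ring in this place gives a measurable inhibition.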